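The compounds below may be only part of what the source reports. "The series", "measured", "known", "first", "only" and "open" are said of these compounds alone.

Measured so far:
Compound 1 `COc1ccc(/C=C/c2cc(OC)cc(OC)c2/C=C/C(=O)c2ccc(Cl)c(Cl)c2)cc1`: 10.8 ug/mL
Compound 2 `CCCC(C)Oc1ccc(C(=O)/C=C/c2c(/C=C/c3ccc(OC)cc3)cc(OC)cc2OC)cc1`: 11.1 ug/mL
Compound 3 `COc1ccc(/C=C/c2cc(OC)cc(OC)c2/C=C/C(=O)c2cccc(Br)c2)cc1`: 13 ug/mL

In a functional assay on HepG2 cells (Homo sapiens) for antiproliferative activity, read by MTT assay, with a stated time of 48 h (on this read-out lower numbers stand for stronger inhibition and higher numbers for weaker inhibition), compound 3 gives 13 ug/mL and cannot be told apart from the other two compounds. The comparisons are a 1.2-fold higher number from compound 1 to compound 3 (0.08 log units; within the scatter) and a 1.2-fold higher number from compound 2 to compound 3 (0.07 log units; within the scatter). The remaining comparison, a 1.0-fold higher number from compound 1 to compound 2 (0.01 log units; within the scatter), is also small. Among these three compounds, then, exchanging the group on the carbonyl carbon has produced no step beyond the scatter.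

The unmeasured compound 4 `CCOc1ccc(C(=O)/C=C/c2c(/C=C/c3ccc(OC)cc3)cc(OC)cc2OC)cc1` departs from compound 3 at that same place: 4-ethoxyphenyl in place of 3-bromophenyl on a carbonyl carbon. It carries 4-ethoxyphenyl in place of 3-bromophenyl on a carbonyl carbon. Among the compounds with values here, no measured compound carries the 4-ethoxyphenyl group itself. The nearest comparison is compound 2, with its 4-(1-methylbutoxy)phenyl on the carbonyl carbon, and the step that bears most directly is a 1.2-fold higher number from compound 2 to compound 3 (0.07 log units; within the scatter). The halogenated pair offers a further reference in a 1.2-fold higher number from compound 1 to compound 3 (0.08 log units; within the scatter). On this evidence, no change beyond the scatter is expected in this assay. The expected result is a 1.1-fold lower number from compound 3 to compound 4 (0.05 log units; within the scatter), a difference too small to read as a real change. For compound 4 the estimated value is 11.5 ug/mL, with an expected range from 6.5 ug/mL to 20 ug/mL.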

Compound 4, half-maximal inhibitory concentration: 8 ug/mL
Compound 4: middle estimate off by 1.4-fold (0.16 log units), on the high side; the range from low to high includes it.
By their numbers in this assay, from the lowest: compounds 4, 1, 2 and 3 (each within the scatter of the next).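

In this assay, 4-ethoxyphenyl in place of 3-bromophenyl on a carbonyl carbon stays within the scatter (a 1.6-fold lower number from compound 3 to compound 4 (0.21 log units; within the scatter)), so an aromatic ring bearing an ether oxygen cannot be told apart here from one bearing a bromine. The two other comparisons read the same way, both for hydrogen in place of propyl on the ether chain (a 1.4-fold lower number from compound 2 to compound 4 (0.14 log units; within the scatter)) and for 4-ethoxyphenyl in place of 3,4-dichlorophenyl (a 1.4-fold lower number from compound 1 to compound 4 (0.13 log units; within the scatter)). With four compounds now in hand, halogen-bearing and ether-bearing aromatic rings on this carbonyl carbon give values that cannot be separated, and none of the four goes against this. Nothing available here accounts for this lack of separation.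

As far as these compounds go, whether an aromatic ring carrying an amine or a carboxylic acid, or a saturated ring such as cyclohexyl, would give a step beyond the scatter at this place remains open. The compounds shown also leave open whether any change elsewhere, such as replacing the methoxy groups of the shared core with longer chains, would separate these values.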